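Swapping the amino side chain on the sulfamate amide

The compounds below may be only part of what the source reports. "The series", "measured", "known", "first", "only" and "open" are said of these compounds alone.

Compound 1 `CCN(Cc1ccc(F)cc1)c1cccc(C(=O)N2CCc3ccc(OS(N)(=O)=O)cc3C2)c1`: 10.9%
Compound 2 `CCN(Cc1ccccc1)c1cccc(C(=O)N2CCc3ccc(OS(N)(=O)=O)cc3C2)c1`: 17.3%
Compound 3 `CN(CCCN1CCCCC1)c1cccc(C(=O)N2CCc3ccc(OS(N)(=O)=O)cc3C2)c1`: 24.1%

The three measured compounds share one core and differ only in the amino substituent on the benzamide ring. In an assay on HEK293 cells for inhibition of Steryl-sulfatase (Homo sapiens), tested at 0.1 uM (a higher number here means a stronger effect of the compound at the concentration tested, a lower number a weaker effect), compound 3 gives the highest of the three numbers, but its margin over compound 2 is a number 6.8 percentage points higher from compound 2 to compound 3 (within the scatter) and only against compound 1 is the gap clear, at a number 13.2 percentage points higher from compound 1 to compound 3 (beyond the scatter). The step of a number 6.4 percentage points higher from compound 1 to compound 2 (within the scatter) likewise stays inside the usual spread.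

Compound 4 `CCN(Cc1cccnc1)c1cccc(C(=O)N2CCc3ccc(OS(N)(=O)=O)cc3C2)c1` has not been tested. Relative to compound 3 the change is ethyl((pyridin-3-yl)methyl)amino in place of methyl(3-(piperidin-1-yl)propyl)amino on an aromatic carbon. The step back toward an ethyl-benzyl-type substituent is what matters here: compound 2 carries the closest analogue of the entering group, and compound 2 gives 17.3% in this assay. The measured steps therefore point to a small downward move rather than a gain, and the expected step is a number 8.1 percentage points lower from compound 3 to compound 4 (within the scatter), which would not exceed the scatter. Compound 4 is estimated at 16%, with a range from 6% to 28%.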

Compound 4, a percentage reported as inhibition, at one concentration (the size of the read-out at that concentration, not a potency): 14.3%
For compound 4 the middle estimate is 1.7 percentage points above the measured one, within the range that was stated.
By their numbers in this assay, from the lowest: compounds 1, 4, 2 and 3 (each within the scatter of the next, the first and the last beyond it).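

In this assay, pyridin-3-yl in place of phenyl on the saturated chain carbon gives a number 3 percentage points lower from compound 2 to compound 4 (within the scatter), and pyridin-3-yl in place of 4-fluorophenyl gives a number 3.4 percentage points higher from compound 1 to compound 4 (within the scatter), so compounds 1, 2 and 4 cannot be told apart by this read-out, whichever of these three aromatic rings the side chain carries. Among these compounds, the larger exchange, ethyl((pyridin-3-yl)methyl)amino in place of methyl(3-(piperidin-1-yl)propyl)amino, gives a number 9.8 percentage points lower from compound 3 to compound 4 (within the scatter), which leaves compound 1 as the only compound separated from compound 3 beyond the scatter. No measurement offered here explains any of these small differences.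

On these data alone, whether a pyridin-4-yl ring on the same chain, or a morpholine in place of the piperidine at the end of the propyl chain, would shift the read-out beyond the scatter remains open. These percentages also come from a single concentration, so the compounds shown leave open how their potencies compare, including whether a real difference lies hidden among compounds 1, 2 and 4.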